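Compound 3, a Pyridinyl Amine Variant, Assessed Against Trypsin

This account rests on a few compounds, and the source may have more. Where it says the series, first, only, none or still open, it means among the compounds named here.

Compound 1 `CN(C)Cc1nccn1-c1ccc(-c2ccc3c(C(N)=O)nn(-c4ccc5onc(N)c5c4)c3c2F)c(F)c1` and compound 2 `CN(C)Cc1cnccc1-c1ccc(-c2ccc3c(C(N)=O)nn(-c4ccc5onc(N)c5c4)c3c2F)c(F)c1` share one core and differ at a single aromatic carbon. In an assay on isolated protein for inhibition of Trypsin (Homo sapiens) (on this read-out higher numbers stand for weaker inhibition and lower numbers for stronger inhibition), compound 1 gives > 10000 nM, which is a limit of the assay rather than a number. In this assay compound 2 likewise gives > 10000 nM, again a limit and not a number. The step that the two limits leave unreadable from compound 1 to compound 2 therefore cannot be read in size or direction. Compound 3 `CN(C)CCN(c1cccnc1)c1ccc(-c2ccc3c(C(N)=O)nn(-c4ccc5onc(N)c5c4)c3c2F)c(F)c1` is not yet measured; it differs from compound 2 in that ((2-(dimethylamino)ethyl)(pyridin-3-yl)amino in place of 3-((dimethylamino)methyl)pyridin-4-yl on an aromatic carbon). Going by the values given here, both measured values sit at the same limit, as summarised in the limit of > 10000 nM in this assay, at which 2 of the 2 values shown sit, so no measured step of readable size bears on this change, and no direction can be taken from the data. Compound 3 is expected to remain at that limit, with the step that the limit leaves unreadable from compound 2 to compound 3 expected to lie within the scatter. Compound 3 is estimated at 20000 nM, within a range from 5000 nM to 100000 nM.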

Compound 3, inhibition constant: > 10000 nM
Compound 3: no number, only a limit; the forecaster's own chance of this, stated with the estimate: 80%; the middle value does not contradict the limit.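

In this assay compound 3 gives > 10000 nM, which is a limit of the assay and not a number. The steps among compound 1, compound 2 and compound 3 therefore cannot be read: the limit of > 10000 nM in this assay, at which 3 of the 3 values shown sit. Still open, from the compounds shown here alone, is whether the group on this aromatic carbon affects inhibition at all.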